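The source may hold more compounds than are shown below. What is called first, only, known or untested is meant among the compounds shown, and "the series" means these compounds.

Working notes on the series. Among the compounds with values here, in an ADME assay on the whole organism (Mus musculus, strain Swiss Webster) for pharmacokinetics, read by LC-MS, at a dose of 50 mg/kg by the oral route (a lower number here means less compound in the circulation, a higher number more compound in the circulation at the dose given), compound 1 (`O=C(Nc1ccc(F)c(-c2nc3ncc(-c4ccc(F)cc4)cc3[nH]2)c1)N1CCCC1`) gives 10200 ng.h/mL and stands lowest of the two numbers so far. Compound 2 (`Cc1nc(C)c(C(=O)Nc2ccc(F)c(-c3nc4ncc(-c5ccccc5Cl)cn4n3)c2)o1`) stands higher with 309000 ng.h/mL and the gap lies beyond the scatter. Compound 3 (`O=C(Nc1ccc(F)c(-c2nc3ncc(-c4ccccc4F)cc3[nH]2)c1)N1CCCC1`) keeps the core of compound 1 and carries 2-fluorophenyl in place of 4-fluorophenyl on an aromatic carbon. Within the data shown here, no measured pair shows this change on its own, and compound 2 differs from compound 1 in more than one place, so the measured numbers give only a thin guide. No step beyond the scatter is expected in this assay and the estimated step is a 1.5-fold higher number from compound 1 to compound 3 (0.17 log units; within the scatter) on present data. For compound 3 the estimated value is 15000 ng.h/mL within an expected range of 5000 ng.h/mL to 45000 ng.h/mL on repeat measurement.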

Compound 3, area under the concentration-time curve: 4870 ng.h/mL
The estimate for compound 3 lay 3.1-fold (0.49 log units) above the measured number; measured number outside the range, below it.
By their numbers in this assay, from the lowest: compound 3; then compound 1; then compound 2.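

In this assay, within the data shown here, this is the first change that can be read on its own: a 2.1-fold lower number from compound 1 to compound 3 (0.32 log units; beyond the scatter). The two compounds have the same atoms, joined differently, so at this position, on an aromatic carbon two atoms from the ring nitrogen, swapping 4-fluorophenyl for 2-fluorophenyl is enough to give a modest step beyond the scatter. No accompanying measurement bears on what lies behind this step.

On these data alone, whether an unsubstituted phenyl or a pyridine ring at this position would give a number nearer compound 1 or compound 3 remains open. Also open, as far as these compounds go, is whether the same change carries the same direction on another core, since compound 2 differs from compound 1 in more than one place and gives no reading on it.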